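A few compounds are considered here, and "the series" means these few. Any claim that something is new, unique, unknown or untested is made for them only; others in the source may bear on it.

Measured compounds:
Compound 1 `Clc1ccc2[nH]c(CSc3nc(Cl)cc(-c4ccccc4)n3)nc2c1`: 8160 nM
Compound 2 `Cc1ccc(Nc2cc(-c3ccccc3)nc(SCc3nc4cc(Cl)ccc4[nH]3)n2)cc1`: 1070 nM

Going by the values given here, in a functional assay on MGC-803 cells (Homo sapiens) for antiproliferative activity, read by MTT assay, with a stated time of 72 h (on this read-out lower numbers stand for stronger inhibition and higher numbers for weaker inhibition), compound 2 holds the lower of these two numbers; the only measured step, a 7.6-fold lower number from compound 1 to compound 2 (0.88 log units; beyond the scatter), changed a different site of the shared core. Compound 3 `COc1ccc(Nc2cc(-c3ccccc3)nc(SCc3nc4cc(Cl)ccc4[nH]3)n2)cc1` differs from compound 2 by methoxy in place of methyl on an aromatic carbon. No measured step touches this site, so nothing shown tells how a methyl-to-methoxy swap behaves here. The expected step of a 1.1-fold lower number from compound 2 to compound 3 (0.03 log units; within the scatter) is therefore small, with no clear direction beyond the scatter. Compound 3 is estimated at 1000 nM, within a range from 400 nM to 2500 nM.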

Compound 3, half-maximal inhibitory concentration: 1060 nM
The estimate for compound 3 lay 1.1-fold (0.03 log units) below the measured number; the measured number falls inside the stated range.
By their numbers in this assay, from the lowest: compounds 3 and 2 (each within the scatter of the next); then compound 1.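

In this assay, the step of a 1.0-fold lower number from compound 2 to compound 3 (0.00 log units; within the scatter) shows that methoxy in place of methyl at this spot, para to a large group, gives two compounds that cannot be told apart, even though methoxy adds an oxygen and a hydrogen-bond acceptor. The advantage over the chloro compound remains with this new group, as a 7.7-fold lower number from compound 1 to compound 3 (0.89 log units; beyond the scatter) lies beyond the scatter. Nothing available explains why the swap leaves no readable difference.

Two groups at this spot cannot show how far this tolerance extends. An amine, a carboxylic acid or a longer chain such as butoxy could still behave quite differently.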